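A few compounds are considered here, and "the series" means these few. Any claim that something is new, unique, unknown or untested is made for them only; others in the source may bear on it.

Measured compounds in a functional assay on SF-539 cells (Homo sapiens) for cytotoxicity, read by sulforhodamine B assay, with a stated time of 48 h; on this read-out higher numbers stand for weaker inhibition of growth and lower numbers for stronger inhibition of growth:

Compound 1, `ClCc1ccccc1Cn1cnc2c(Cl)ncnc21`, gives 24000 nM.
Compound 2, `ClCc1cccc(Cn2cnc3ncnc(Cl)c32)c1`, gives 36300 nM.
Compound 3, `ClCc1cccc(Cn2cnc3c(Cl)ncnc32)c1`, gives 35500 nM.

Compound 2 carries the highest of the three numbers in this assay, but its gap to compound 3 and its gap to compound 1 both lie within the usual scatter, so no order among the three can be read from these values. Among the compounds with values here, no pair of measured compounds differs in only one place, so no single-change step is available from which to calibrate the next change.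

Compound 4, `ClCc1cccc(Cn2cnc3nc(Cl)nc(Cl)c32)c1`, has not yet been measured. It differs from compound 2 by chloro in place of hydrogen on an aromatic carbon. Within the data shown here, with no comparable step among the measured compounds, the expectation is that the step from compound 2 to compound 4 in this assay will be small, most likely not beyond the scatter, with a mild lean toward a lower number: expected a 1.5-fold lower number from compound 2 to compound 4 (0.16 log units; within the scatter). On that basis compound 4 is estimated at 25000 nM, with a plausible range from 8000 nM to 80000 nM.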

Compound 4, concentration for total growth inhibition: 460 nM
Compound 4: the middle estimate sits 54-fold (1.74 log units) above what was measured; measured number below the stated range.
By their numbers in this assay, from the lowest: compound 4; then compounds 1, 3 and 2 (each within the scatter of the next).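

In this assay, within the data shown here, chloro in place of hydrogen on an aromatic carbon between two ring nitrogen atoms gives a 79-fold lower number from compound 2 to compound 4 (1.90 log units; beyond the scatter), the first single-change step and one well beyond the scatter. Among these compounds, this position on the six-membered aromatic ring with 2 nitrogen is therefore highly sensitive to substitution, which the earlier compounds could not show, since no two of them differ in only one place. Nothing available accounts for the size of this step.

Whether the step depends on chloro itself remains open, as the position is shown only with hydrogen and chloro and not with an amine, a methoxy group or a methyl group. Also open, on these data alone, is whether the same change gives a step of similar size on the cores of compound 1 and compound 3.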